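The compounds below may be only part of what the source reports. "The series", "measured", "known", "first", "only" and "open" are said of these compounds alone.

Measured so far:
compound 1 `COC1C=C(CCC/C(C)=C\CC/C(C)=C\CC[C@@H](C)/C=C2\OC(=O)C(C)=C2O)C(OC)O1` — 83 ug/mL
compound 2 `COC(=O)C(C)(O)[C@@](O)(C[C@H](C)CC/C=C(/C)CC/C=C(/C)CCCc1ccoc1)C(=O)OC` — 46 ug/mL

In a functional assay on K562 cells (Homo sapiens) for cytotoxicity, read by MTT assay (on this read-out higher numbers stand for lower toxicity in this test and lower numbers for higher toxicity in this test), compound 1 gives 83 ug/mL, the higher of the two numbers, but its gap to compound 2, which gives 46 ug/mL, lies within the scatter, so the two are not told apart here.

Compound 3 `CC1=C(O)/C(=C/[C@H](C)CC/C=C(/C)CC/C=C(/C)CCCC2=CC(O)OC2=O)OC1=O` differs from compound 1 by a group of 7 heavy atoms (4 carbon, 3 oxygen; one five-membered non-aromatic ring with 1 hetero atom) in place of a group of 9 heavy atoms (6 carbon, 3 oxygen; one five-membered non-aromatic ring with 1 hetero atom), on a saturated chain carbon, three bonds along the chain from a double-bonded chain carbon. Among the measured compounds shown here, no measured pair shows a change of this kind, so the size of the step is open. The expectation is a step from compound 1 to compound 3 of a 1.8-fold lower number from compound 1 to compound 3 (0.27 log units; within the scatter) in this assay, toward lower numbers, not clearly beyond the scatter. Compound 3 is estimated at 45 ug/mL, with a range of 15 ug/mL to 130 ug/mL.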

Compound 3, concentration lethal to 50% of the cells: > 100 ug/mL
Compound 3 gave a limit, no number (the forecaster's own chance of this, stated with the estimate: 10%); at least 2.2-fold (0.34 log units) between middle value and limit.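

In this assay the group of 7 heavy atoms in place of the group of 9 heavy atoms gives an at least 1.2-fold higher number from compound 1 to compound 3 (0.08 log units; that floor lies within the scatter) and so no sign of a lower number on this saturated chain carbon. Among the compounds shown here, this is the first reading for a change at this place, and its floor does not separate compound 3 from compound 1. Compound 3 is read only as a limit, so the size of the step stays unknown: the limit of > 100 ug/mL in this assay, at which 1 of the 3 values shown sits.

As far as these compounds go, whether a carboxylic acid or an amine on this chain carbon would give a number inside the range of the assay remains open.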